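A few compounds are considered here, and "the series" means these few. Any claim that something is new, unique, unknown or untested is made for them only; others in the source may bear on it.

Compound 1 `COc1cc(N)c(Cl)cc1NC(=O)C1CCN(Cc2ccc(Cl)cc2)CC1` gives 1.2 mg/kg.
Compound 2 `COc1cc(N)c(Cl)cc1NC(=O)C1CCN(CC2CCCC2)CC1` reaches only a limit of the assay, > 10 mg/kg.
Compound 3 `COc1cc(N)c(Cl)cc1NC(=O)C1CCN(Cc2ccc(C)c(C)c2)CC1` reaches only a limit of the assay, > 8 mg/kg.

The three compounds share one core and differ only in the group on a saturated chain carbon bound to an amine nitrogen in a ring. Among the compounds with values here, in a functional assay on the whole organism for antagonist activity, with Mus musculus as the target (on this read-out higher numbers stand for an effect only at larger amounts of compound and lower numbers for an effect already at smaller amounts), compound 1, with 4-chlorophenyl there, is the one compound that gives a number. Compound 2 sits at the limit of > 10 mg/kg in this assay, at which 1 of the 3 values shown sits, and is a limit, not a number. Compound 3 sits at the limit of > 8 mg/kg in this assay, at which 1 of the 3 values shown sits, and is likewise a limit. The two steps away from compound 1 are an at least 8.3-fold higher number from compound 1 to compound 2 (0.92 log units; beyond the scatter) and an at least 6.6-fold higher number from compound 1 to compound 3 (0.82 log units; beyond the scatter), both beyond the scatter. Between the two limits, a step that the two limits leave unreadable from compound 2 to compound 3.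

Compound 4 `CCN1CCC(C(=O)Nc2cc(Cl)c(N)cc2OC)CC1` changes compound 3 by methyl in place of 3,4-dimethylphenyl on a saturated chain carbon bound to an amine nitrogen in a ring. Within the data shown here, the only change so far that left this position with something other than 4-chlorophenyl pushed the value to a limit, as in compound 2 and compound 3, so a further shrinking to methyl is expected to leave the value at a limit as well. Compound 4 is therefore expected to give about 15 mg/kg in this assay, within 5 mg/kg to 50 mg/kg. The expected step is a step that the limit leaves unreadable from compound 3 to compound 4, which the limit at compound 3 makes hard to read.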

Compound 4, dose for half-maximal effect: > 10 mg/kg
Compound 4 ended at the assay's limit (the forecaster's own chance of this, stated with the estimate: 70%); the middle value is on the limit's open side.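

Shrinking the group from 3,4-dimethylphenyl, with 8 heavy atoms and an aromatic ring, to methyl, with 1 heavy atom and no ring, still yields no number in this assay. Replacing 4-chlorophenyl with methyl gives an at least 8.3-fold higher number from compound 1 to compound 4 (0.92 log units; beyond the scatter), so methyl joins cyclopentyl and 3,4-dimethylphenyl as a replacement that falls short, and compound 1 remains the only one of the four that gives a number. The steps among compound 2, compound 3 and compound 4 cannot be read, and compound 4 shares its limit with compound 2, so these groups cannot be placed in any order by size: the limit of > 10 mg/kg in this assay, at which 2 of the 4 values shown sit.

The compounds shown do not separate the part played by the chlorine from that of the aromatic ring, and a plain phenyl in this place would speak to that question, while a longer chain such as butyl would test whether any other simple chain gives a number. As far as these compounds go, how far the true values of compound 2, compound 3 and compound 4 lie beyond their limits also stays open.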